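Solubility on a shared core: a third variant

This account rests on a few compounds, and the source may have more. Where it says the series, first, only, none or still open, it means among the compounds named here.

Measured so far:
- compound 1, `O=C1O[C@@H](Cn2ccnn2)CN1c1ccc(-c2ccc(CO)nc2)c(F)c1`: 100000 nM
- compound 2, `CN1CCN(CCCC(=O)c2ccc(-c3ccc(N4C[C@H](Cn5ccnn5)OC4=O)cc3F)cn2)CC1`: > 400000 nM

Compound 1 carries a hydroxymethyl group on an aromatic carbon of the shared core. Among the compounds with values here, in a physicochemical assay for solubility, read by nephelometry (a higher number here means a more soluble compound, a lower number a less soluble compound), compound 1 gives 100000 nM, the only plain number recorded here. Compound 2 replaces that hydroxymethyl with a (3-(4-methylpiperazin-1-yl)propyl)carbonyl group. In this assay compound 2 reaches only a limit of the measurement, > 400000 nM, so its true value is not known. The measured step of an at least 4.0-fold higher number from compound 1 to compound 2 (0.60 log units; beyond the scatter) is therefore a lower bound, resting on (the limit of > 400000 nM in this assay, at which 1 of the 2 values shown sits).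

Compound 3, `O=C1O[C@@H](Cn2ccnn2)CN1c1ccc(-c2ccc(C(O)C3CNC3)nc2)c(F)c1`, differs from compound 1 by azetidin-3-yl in place of hydrogen on a saturated chain carbon bound to an aromatic carbon and an oxygen on a saturated carbon. Like compound 2, it adds a nitrogen-containing saturated ring, though a much smaller one and at a different place. Within the data shown here, the only measured step that bears on it is the change from compound 1 to compound 2, which was at least modest and upward. For compound 3 a smaller upward step is expected, a 2.5-fold higher number from compound 1 to compound 3 (0.40 log units; beyond the scatter), giving an estimated 250000 nM in this assay, with a range from 100000 nM to 500000 nM, and a fair chance that only a limit is reported.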

Compound 3, solubility: > 400000 nM
Compound 3: no number, only a limit (the forecaster's own chance of this, stated with the estimate: 35%); middle value at least 1.6-fold (0.20 log units) from the limit.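

In this assay, azetidin-3-yl in place of hydrogen on a saturated chain carbon bound to an aromatic carbon and an oxygen on a saturated carbon gives an at least 4.0-fold higher number from compound 1 to compound 3 (0.60 log units; beyond the scatter). A step beyond the scatter is therefore no longer tied to the (3-(4-methylpiperazin-1-yl)propyl)carbonyl group of compound 2: one four-membered non-aromatic ring with a single hetero atom, at a different place, also comes with such a step. Compound 3 gives only a limit, so its step is a lower bound, and the step between compound 2 and compound 3 cannot be read, because both compounds stop at a limit: the limit of > 400000 nM in this assay, at which 2 of the 3 values shown sit.

From the compounds shown here alone, how far compound 2 and compound 3 lie beyond that limit stays open, so the large group and the small one cannot be ranked. Also open, going by these compounds, is whether the ring nitrogen is what counts, which an oxetan-3-yl group, with oxygen in its place, or an open-chain aminomethyl group on the same carbon would help to show.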